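Ring-carbon substituent series: ethyl to phenyl

This account rests on a few compounds, and the source may have more. Where it says the series, first, only, none or still open, it means among the compounds named here.

The shared core is represented by compound 1 `N#C/N=C1\N(CCCCCOc2ccc(Cl)cc2)C(=O)CN1c1ccncc1`, which in a functional assay on HONE1 cells for cytotoxicity against HONE1 cell line (Homo sapiens) (a higher number here means a weaker inhibitor, a lower number a stronger inhibitor), gives 3400 nM. Compound 2 `CC1C(=O)N(CCCCCOc2ccc(Cl)cc2)/C(=N\C#N)N1c1ccncc1` gives 3680 nM, and compound 3 `CCC1C(=O)N(CCCCCOc2ccc(Cl)cc2)/C(=N\C#N)N1c1ccncc1` gives 4830 nM. Compound 3 holds the highest of the three numbers, although a 1.4-fold higher number from compound 1 to compound 3 (0.15 log units; within the scatter) and a 1.3-fold higher number from compound 2 to compound 3 (0.12 log units; within the scatter) both sit within the scatter, as does a 1.1-fold higher number from compound 1 to compound 2 (0.03 log units; within the scatter). Compound 4 `N#C/N=C1\N(CCCCCOc2ccc(Cl)cc2)C(=O)C(c2ccccc2)N1c1ccncc1` differs from compound 3 by phenyl in place of ethyl on a saturated ring carbon. Among the compounds with values here, the steps that bear on this change are the hydrogen-to-alkyl changes on the saturated ring carbon; all were small, and nothing measured covers an aromatic ring there. The step of a 1.1-fold higher number from compound 3 to compound 4 (0.06 log units; within the scatter) is therefore expected to stay near the scatter, with wide uncertainty. Compound 4 is estimated at 5500 nM, range 2500 nM to 12000 nM.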

Compound 4, half-maximal inhibitory concentration: 373 nM
Estimate against measurement, compound 4: 15-fold (1.17 log units) above, outside the stated range (below it).
By their numbers in this assay, from the lowest: compound 4; then compounds 1, 2 and 3 (each within the scatter of the next).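

On the saturated ring carbon, hydrogen, methyl and ethyl stay within the scatter of one another in this assay, but phenyl separates clearly from all three (a 13-fold lower number from compound 3 to compound 4 (1.11 log units; beyond the scatter); a 9.9-fold lower number from compound 2 to compound 4 (0.99 log units; beyond the scatter); a 9.1-fold lower number from compound 1 to compound 4 (0.96 log units; beyond the scatter)). This position therefore does respond to substitution, and among the groups shown that response appears only with the aromatic ring of compound 4. Nothing available explains the shift.

Still open, as far as these compounds go, is whether a cyclohexyl, a benzyl or a methoxyphenyl group on this carbon would track with phenyl or with the alkyl groups.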